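An ethyl amide takes the place of a free acid

This account rests on a few compounds, and the source may have more. Where it says the series, first, only, none or still open, it means among the compounds named here.

Values in a functional assay (aorta) with Rattus norvegicus as the target; on this read-out higher numbers stand for weaker inhibition and lower numbers for stronger inhibition:
Compound 1 `CCOC(=O)CN(c1ccccc1)C1c2cc(C#N)ccc2OC(C)(C)C1O`: > 30000 nM (a limit)
Compound 2 `CC1(C)Oc2ccc(C#N)cc2[C@H](N(CC(=O)O)c2ccccc2)[C@H]1O`: > 100000 nM (a limit)

Compound 2 gives no number on this read-out, only a limit, > 100000 nM. Compound 1 likewise gives only a limit, > 30000 nM. Among the measured compounds shown here, with two limits and no number, no measured step is available to show how large a change can be.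

Compound 3 `CCNC(=O)CN(c1ccccc1)[C@H]1c2cc(C#N)ccc2OC(C)(C)[C@@H]1O` keeps the shared core of compound 2 and alters one group, carboxy to ethylcarbamoyl: ethylamino in place of hydroxy on a carbonyl carbon. In words, ethylamino stands in place of hydroxy on a carbonyl carbon.

A modest shift towards stronger inhibition is expected, though compound 3 may well remain a limit too. That caution rests on compound 1, which also has no carboxy and still shows only a limit, > 30000 nM. The expected change, a rough estimate, is an at least 3.3-fold lower number from compound 2 to compound 3 (0.52 log units; beyond the scatter). For compound 3 the estimated value in this assay is 30000 nM, with an expected range of 8000 nM to 100000 nM.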

Compound 3, half-maximal inhibitory concentration: > 30000 nM
Compound 3 was reported as a limit; the forecaster's own chance of this, stated with the estimate: 55%; the middle value lies on the limit itself.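

In this assay compound 3 gives > 30000 nM, which is a limit and not a number. Compound 2 gives > 100000 nM, also a limit. Among the compounds shown here, no step can therefore be read between compound 2 and compound 3. The compounds shown leave open whether ethylamino in place of hydroxy on a carbonyl carbon changes inhibition at all.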